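This account rests on a few compounds, and the source may have more. Where it says the series, first, only, none or still open, it means among the compounds named here.

Compound 1, `Cc1c(C=O)cc(-c2ccc(S(C)(=O)=O)cc2)n1-c1ccc(F)c(F)c1`: in an assay on J774 cells for inhibition of prostaglandin G/H synthase 1 (Mus musculus), read by immunoassay, with stated times of 15 min and 30 min (a lower number here means a stronger inhibitor, a higher number a weaker inhibitor), compound 1 gives > 10000 nM, a limit of the assay.
Compound 2, `Cc1c(/C=N\O)cc(-c2ccc(S(C)(=O)=O)cc2)n1-c1ccc(F)c(F)c1`: in this assay compound 2 gives > 10000 nM, also a limit.
Compound 3, `Cc1c(C#N)cc(-c2ccc(S(C)(=O)=O)cc2)n1-c1cccc(F)c1`: in this assay compound 3 gives > 10000 nM, again a limit.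

All three measured compounds share the same core and the same methylsulfonylphenyl group, and none of them gives a number in this assay. Among the measured compounds shown here, the only measured step, a step that the two limits leave unreadable from compound 1 to compound 2, runs between two limits and its size cannot be read. Compound 3 therefore stands nowhere in particular on the numbers shown: it sits where every value sits, as the limit of > 10000 nM in this assay, at which 3 of the 3 values shown sit, records.

Compound 4, `Cc1c(C#N)cc(-c2ccc(S(C)(=O)=O)cc2)n1-c1ccc(F)c(F)c1`, differs from compound 3 by fluoro in place of hydrogen on an aromatic carbon. This change brings compound 4 to the same 3,4-difluorophenyl group that compound 1 and compound 2 carry. No measured step speaks directly to this change, but the 3,4-difluorophenyl compounds give no number either, and nothing shown suggests a step beyond the scatter. Compound 4 is expected to remain at the limit as well, with an estimated step that the limit leaves unreadable from compound 3 to compound 4. The estimate for compound 4 in this assay is 30000 nM, within a range from 10000 nM to 100000 nM.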

Compound 4, half-maximal inhibitory concentration: > 10000 nM
Compound 4 was reported as a limit; the forecaster's own chance of this, stated with the estimate: 90%; the middle value is on the limit's open side.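

Compound 4 gives only a limit, > 10000 nM in this assay, so its steps from compound 1, compound 2 and compound 3 cannot be read. Left open is how far any of these changes shifts inhibition, because every value shown is the same limit: the limit of > 10000 nM in this assay, at which 4 of the 4 values shown sit.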